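Iodo in place of furan-3-yl, starting from a limit

The source may hold more compounds than are shown below. What is called first, only, known or untested is meant among the compounds shown, and "the series" means these compounds.

In a functional assay on CCRF-CEM cells (Homo sapiens), read by MTT assay, with a stated time of 72 h (a higher number here means a weaker inhibitor, a lower number a stronger inhibitor), compound 1 (`CNc1ncnc2c1c(-c1ccoc1)cn2[C@@H]1O[C@H](CO)[C@@H](O)[C@H]1O`) gives > 20000 nM as a limit only. Compound 2 (`Cc1ncnc2c1c(-c1ccoc1)cn2[C@@H]1O[C@H](CO)[C@@H](O)[C@H]1O`) also gives > 20000 nM as a limit. Within the data shown here, both compounds thus sit at the limit of > 20000 nM in this assay, at which 2 of the 2 values shown sit, and the only measured change, a step that the two limits leave unreadable from compound 1 to compound 2, has no readable size and lies at another place. Compound 3 (`CNc1ncnc2c1c(I)cn2[C@@H]1O[C@H](CO)[C@@H](O)[C@H]1O`) carries iodo in place of furan-3-yl on an aromatic carbon of the shared core. A modest, uncertain move towards stronger inhibition in this assay is expected, estimated as an at least 2.5-fold lower number from compound 1 to compound 3 (0.39 log units; beyond the scatter) overall. For compound 3 the estimated value is 8000 nM within an expected range of 1000 nM to 40000 nM in this estimate.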

Compound 3, half-maximal inhibitory concentration: > 100000 nM
Compound 3: no number, only a limit (the forecaster's own chance of this, stated with the estimate: 45%); middle value at least 12-fold (1.09 log units) away from the limit.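

Compound 1 and compound 3 both give only limits in this assay, so the step between them cannot be read. The compounds shown leave open what actual number any of the three would reach in this assay.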